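4-(Dimethylamino)phenyl gives way to 3-chlorophenyl

This account rests on a few compounds, and the source may have more. Where it says the series, first, only, none or still open, it means among the compounds named here.

Two measured compounds set the scale for this series. In a functional assay on ZR-75-1 cells (Homo sapiens) for inhibition, read by sulforhodamine B assay (a higher number here means a weaker inhibitor of growth, a lower number a stronger inhibitor of growth), compound 1 (`c1ccc(-c2ccc(-c3ccc(-c4nc5ccccc5[nH]4)cc3)cc2)cc1`) gives 100000 nM as its concentration for half-maximal growth inhibition. Compound 2 (`Cc1ccc2[nH]c(-c3ccc(-c4ccc(-c5ccc(N(C)C)cc5)cc4)cc3)nc2c1`) gives 7200 nM on the same read-out and so holds the lower of the two numbers, with a gap beyond the scatter. These two compounds differ in more than one place, so the gap cannot be tied to any single group.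

Compound 3 (`Cc1ccc2[nH]c(-c3ccc(-c4ccc(-c5cccc(Cl)c5)cc4)cc3)nc2c1`) has not yet been measured. It keeps the rest of compound 2 but carries 3-chlorophenyl in place of 4-(dimethylamino)phenyl on an aromatic carbon of the shared core. Among the measured compounds shown here, no measured step shows what this swap does by itself. For the measured compounds named here, the only hint is compound 1, which also lacks the 4-(dimethylamino)phenyl group and gives 100000 nM in this assay as the weaker of the pair. The expected change is a 3.1-fold higher number from compound 2 to compound 3 (0.49 log units; beyond the scatter) toward a higher number, a modest loss beyond the scatter. For compound 3 the estimated value is 22000 nM with an expected range from 6000 nM to 80000 nM on this read-out.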

Compound 3, concentration for 50% growth inhibition: 3450 nM
Beside the measured number, compound 3's estimate is 6.4-fold (0.80 log units) above it, outside the stated range (below it).
By their numbers in this assay, from the lowest: compound 3; then compound 2; then compound 1.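

In this assay the series now has its first step that changes one place only: a 2.1-fold lower number from compound 2 to compound 3 (0.32 log units; beyond the scatter) with 3-chlorophenyl in place of 4-(dimethylamino)phenyl on an aromatic carbon para to a large group. The step is modest but beyond the scatter, and it shows that this position does not need the 4-(dimethylamino)phenyl group, since growth inhibition is kept and somewhat strengthened once that group's nitrogen and its hydrogen-bond acceptor are gone and a chlorine-bearing ring stands there instead. Nothing measured here explains why the number moves in this direction.

The compounds shown leave open whether the chlorine itself matters, which a fluorine, a methoxy group or an amine in its place on the same ring would begin to test. Among the compounds shown here, they also leave the methyl group on the shared core unresolved, as no single step isolates what it contributes to growth inhibition, and so the wide gap that opened the series still cannot be divided between its separate changes.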